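The source may hold more compounds than are shown below. What is called first, only, known or untested is meant among the compounds shown, and "the series" means these compounds.

Compounds measured in a functional assay on the whole organism (strain Wistar) for inhibition, with Rattus norvegicus as the target, read by paw edema, with stated times of 1 h and 4 h, at a dose of 70 mg/kg by the oral route; on this read-out lower numbers stand for less inhibition and higher numbers for more inhibition at the one dose given (going by the name of the read-out):
compound 1, `Clc1ccc2nc(Nc3nnc(-c4ccccc4Cl)o3)sc2c1`, 53.2%
compound 2, `Clc1ccc(-c2nnc(Nc3nc4ccc(Cl)cc4s3)o2)c(Cl)c1`, 87.1%
compound 3, `COC(=O)c1ccccc1-c1nnc(Nc2nc3ccc(Cl)cc3s2)o1`, 50.8%

Compound 2 stands highest of the three numbers. Its nearest neighbour is compound 1, and the step of a number 33.9 percentage points higher from compound 1 to compound 2 (beyond the scatter) is beyond the scatter; its furthest is compound 3, lower still. Between compound 1 and compound 3 the step of a number 2.4 percentage points lower from compound 1 to compound 3 (within the scatter) lies within the scatter, so those two cannot be placed in any order.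

Compound 4, `Clc1ccc2nc(Nc3nnc(Oc4ccccc4)o3)sc2c1`, has not yet been measured. It differs from compound 2 in one place: phenoxy in place of 2,4-dichlorophenyl on an aromatic carbon. For the measured compounds named here, only one measured step bears on this change. Going by the values given here, the step of a number 33.9 percentage points higher from compound 1 to compound 2 (beyond the scatter) shows that adding chloro to the phenyl ring raised the read-out by a large amount; going from compound 2 to compound 4 removes both chloro groups and also exchanges the direct ring link for phenoxy, a change for which no measured pair exists. The expectation therefore rests on the loss of chloro alone, and a large downward step is expected, a number 42.1 percentage points lower from compound 2 to compound 4 (beyond the scatter). Compound 4 is estimated to give 45% in this assay, within a range from 28% to 62%.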

Compound 4, a percentage reported as inhibition, in the whole organism at one dose (the size of the read-out at that dose, not a potency): 88.8%
Compound 4: the middle estimate sits 43.8 percentage points below what was measured; the whole stated range lies below it.
By their numbers in this assay, from the lowest: compounds 3 and 1 (each within the scatter of the next); then compounds 2 and 4 (each within the scatter of the next).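

In this assay, the carbon of the five-membered aromatic ring with 2 nitrogen and 1 oxygen carries phenoxy as well as it carries 2,4-dichlorophenyl: the step of a number 1.7 percentage points higher from compound 2 to compound 4 (within the scatter) leaves the two compounds indistinguishable, so chloro on a directly attached phenyl ring is not the only way to reach the top of this small set. Compared with the 2-chlorophenyl group at the same place, phenoxy brings a large rise, a number 35.6 percentage points higher from compound 1 to compound 4 (beyond the scatter), which shows that a high read-out here can come with no chloro on the ring at all. Nothing at hand explains why these two different groups read alike.

Going by these compounds, how a plain phenyl at this place would read remains open, and without it the effect of the oxygen link cannot be separated from that of the chloro groups. Also open, on these data alone, is whether 2,4-dichlorophenoxy, an amine or a longer alkyl chain at this carbon would hold the read-out at the level of compound 2 and compound 4 or move it away.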